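Methoxy for Bromo on the Anilino Ring of Compound 1

The compounds below may be only part of what the source reports. "The series", "measured", "known", "first", "only" and "open" are said of these compounds alone.

Compound 1 `Brc1cccc(Nc2nc(-c3ccncc3)cs2)c1` gives 40700 nM in a functional assay on RCC4 cells (Homo sapiens) for inhibition, read by XTT assay, with a stated time of 4 days (a higher number here means a weaker inhibitor, a lower number a stronger inhibitor), the only number among its entries, the remaining two being recorded without a single value; this puts compound 1 at the high end of the numbers shown. Compound 2 `Cc1cccc(Nc2nc(-c3ccnc(-c4cn(Cc5ccccc5)nn4)c3)cs2)c1` gives 2100 nM; 2140 nM (2 entries) in this assay, its repeated entries agreeing (the several entries of compound 2 in this assay, 2100 nM; 2140 nM (2 entries)). Compound 3 `Cc1cccc(Nc2nnc(-c3ccncc3)n2C)c1` gives > 40000 nM; 40700 nM (2 entries) in this assay, its repeated entries shown together (the several entries of compound 3 in this assay, > 40000 nM; 40700 nM (2 entries)).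

Compound 4 `COc1cccc(Nc2nc(-c3ccncc3)cs2)c1` differs from compound 1 by methoxy in place of bromo on an aromatic carbon. For the measured compounds named here, no measured step covers this change, so any shift is expected to be small, within the scatter or a modest gain. Compound 4 is expected at 30000 nM in this assay, between 8000 nM and 45000 nM. The expected change is a 1.4-fold lower number from compound 1 to compound 4 (0.13 log units; within the scatter).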

Compound 4, half-maximal inhibitory concentration: 3020 nM
Compound 4: the middle estimate sits 9.9-fold (1.00 log units) above what was measured; measured number below the stated range.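

In this assay, methoxy in place of bromo on an aromatic carbon gives a 13-fold lower number from compound 1 to compound 4 (1.13 log units; beyond the scatter), so this position, meta to a large group, can move the read-out well beyond the scatter. The earlier compounds shown here held no single-place step here and could not show this. No measured information among the compounds shown bears on the cause of this step.

Still open, as far as these compounds go, is whether the step belongs to methoxy specifically or to the loss of bromo. An amine, a hydroxyl or a longer alkoxy chain at this place would help separate the two.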